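Allyl-substituted bis-benzylidene series: cytotoxicity in U-937 cells

The source may report more compounds than this note shows. Statements on the series, on what has been measured and on what is new or still open speak of the compounds shown alone.

Measured compounds:
compound 1 `C=CCn1c(=O)/c(=C\c2cc(Br)ccc2F)[nH]c(=O)/c1=C\c1ccccc1OC` — 4700 nM
compound 2 `C=CCn1c(=O)/c(=C\c2ccc(F)c(Br)c2)[nH]c(=O)/c1=C\c1ccccc1OC` — "not active" (no number reported)

In a functional assay on U-937 cells (Homo sapiens) for cytotoxicity, read by CCK-8 assay, with a stated time of 72 h (on this read-out lower numbers stand for stronger inhibition and higher numbers for weaker inhibition), compound 1 gives 4700 nM. In this assay compound 2 is recorded only as "not active" (no number reported), so no single number places it against compound 1. Compound 3 `C=CCn1c(=O)/c(=C\c2ccccc2F)[nH]c(=O)/c1=C\c1ccccc1OC` carries 2-fluorophenyl in place of 3-bromo-4-fluorophenyl on a double-bonded chain carbon bound to an aromatic carbon. For the measured compounds named here, no measured step covers this change; as compound 2 has no number, the size and direction of the step cannot be expected with any confidence. Compound 3 is expected near 9000 nM, with a range of 2500 nM to 40000 nM, and a fair chance that only a limit is reported.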

Compound 3, half-maximal inhibitory concentration: 5500 nM
The estimate for compound 3 lay 1.6-fold (0.21 log units) above the measured number; low and high end bracket the measured number.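

In this assay, hydrogen in place of bromo on an aromatic carbon gives a 1.2-fold higher number from compound 1 to compound 3 (0.07 log units; within the scatter), so this bromo can be removed from compound 1 without a step beyond the scatter. For the compounds shown here, compound 2 has no number, so no step involving it can be read. Nothing measured here accounts for the flat step.

Open is whether the remaining fluoro matters, since an unsubstituted phenyl or a ring carrying an amine or a carboxylic acid is not among the compounds shown. Also open, as far as these compounds go, is how a longer chain in place of the allyl group would read.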